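Chalcone-bearing fused pyrazole series: antiproliferative notes, first step

The source may report more compounds than this note shows. Statements on the series, on what has been measured and on what is new or still open speak of the compounds shown alone.

Measured so far:
compound 1 `COc1ccc(C(=O)/C=C/c2cc(-c3ccc(OC)c(OC)c3)n3nc(-c4ccccc4)cc3n2)cc1` gives 13900 nM
compound 2 `COc1ccc(/C=C/C(=O)c2cc(-c3cc(OC)c(OC)c(OC)c3)n3nc(-c4ccccc4)cc3n2)cc1OC` gives 14200 nM
compound 3 `COc1cc(-c2cc(/C=C/C(=O)c3ccc(C)cc3)nc3cc(-c4ccccc4)nn23)cc(OC)c1OC` gives 23900 nM

All three numbers come from a functional assay on MDA-MB-231 cells (Homo sapiens) for antiproliferative activity, read by MTT assay, with a stated time of 24 h; a lower number here means a stronger inhibitor, a higher number a weaker inhibitor. Compound 1 stands at one end of the three values, but compound 2 and compound 3 both sit within the usual scatter of it, so the three are not separated from one another in this assay. Nothing in the set so far shows one member pulling clear of the rest.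

The next compound is compound 4 `COc1ccc(-c2cc(C(=O)/C=C/c3ccc(C)cc3)nc3cc(-c4ccccc4)nn23)cc1OC`. It differs from compound 1 in one place: (2-(4-methylphenyl)ethenyl)carbonyl in place of 2-((4-methoxyphenyl)carbonyl)ethenyl on an aromatic carbon. The carbonyl and ethenyl groups of the side chain change order relative to the core, and a methyl group replaces a methoxy group on the attached ring.

Within the data shown here, no step between two measured compounds is available to calibrate this change. Compound 3, which also carries the (2-(4-methylphenyl)ethenyl)carbonyl arrangement, gives 23900 nM in this assay, a value within the scatter of compound 1. On that basis the step is expected to be small, a 1.3-fold higher number from compound 1 to compound 4 (0.11 log units; within the scatter), with no direction beyond the scatter. Compound 4 is therefore estimated at 18000 nM in this assay, with a range from 8000 nM to 40000 nM.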

Compound 4, half-maximal inhibitory concentration: 22600 nM
For compound 4 the middle estimate is 1.3-fold (0.10 log units) below the measured one; the range from low to high includes it.
By their numbers in this assay, from the lowest: compounds 1, 2, 4 and 3 (each within the scatter of the next).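

In this assay, the side chain on this aromatic carbon, next to the ring nitrogen, can be changed from 2-((4-methoxyphenyl)carbonyl)ethenyl to (2-(4-methylphenyl)ethenyl)carbonyl with a measured result of a 1.6-fold higher number from compound 1 to compound 4 (0.21 log units; within the scatter), which gives the series its first direct reading at this position. The reversed order of the carbonyl and ethenyl groups and the replacement of methoxy by methyl on the attached ring arrive together in this single step, and together they leave compound 1 and compound 4 unseparated, so this combined change does not distinguish the two side chains here. No measured property of either side chain is available to account for the size of the step.

The shared step leaves open what each part of the change does alone, since the order of the carbonyl and ethenyl groups and the methoxy-to-methyl replacement cannot be read separately from these compounds. Also open, from the compounds shown here alone, is whether a carboxylic acid or a dimethylamino group on the attached ring, or a saturated two-carbon link in place of the ethenyl group, would move the number beyond the scatter.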